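A Benzoyl Ester of the Hydroxypropyl Triazole

The source may report more compounds than this note shows. Statements on the series, on what has been measured and on what is new or still open speak of the compounds shown alone.

Three compounds sharing one core have been examined in an ADME assay on HepG2 cells (Homo sapiens) for cytotoxicity, read by MTT assay, with a stated time of 24 h; on this read-out lower numbers stand for higher toxicity in this test and higher numbers for lower toxicity in this test. Compound 1 `Cc1ccc(-c2cn(-c3ccnc4cc(Cl)ccc34)nn2)cc1` gives 352000 nM. Compound 2 `OCCCc1cn(-c2ccnc3cc(Cl)ccc23)nn1` gives 151000 nM, and compound 3 `CC(C)(O)c1cn(-c2ccnc3cc(Cl)ccc23)nn1` gives 442000 nM. On these numbers compound 2 stands lowest of the three: the step of a 2.3-fold lower number from compound 1 to compound 2 (0.37 log units; beyond the scatter) and the step of a 2.9-fold higher number from compound 2 to compound 3 (0.47 log units; beyond the scatter) both lie beyond the scatter, while the step of a 1.3-fold higher number from compound 1 to compound 3 (0.10 log units; within the scatter) does not.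

Compound 4 `O=C(OCCCc1cn(-c2ccnc3cc(Cl)ccc23)nn1)c1ccccc1` is compound 2 with a change at the hydroxyl: benzoyl in place of hydrogen on an oxygen on a saturated carbon. For the measured compounds named here, no measured step exchanges a hydrogen on an oxygen for an acyl group, so none bears on this change directly. What the measured steps do show is that exchanging the whole substituent on the aromatic carbon, as in the step from compound 1 to compound 2 and the step from compound 2 to compound 3, moved the read-out only modestly in either direction. Compound 4 keeps the 3-hydroxypropyl chain of compound 2 and adds a benzoyl to its oxygen, so a step of similar modest size is expected, most likely toward a lower number, from compound 2 to compound 4, namely a 1.7-fold lower number from compound 2 to compound 4 (0.22 log units; within the scatter). Compound 4 is therefore expected to give about 90000 nM, with a range from 35000 nM to 250000 nM.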

Compound 4, half-maximal cytotoxic concentration: 1200000 nM
Estimate against measurement, compound 4: 13-fold (1.12 log units) below, and the stated range ends below it.
By their numbers in this assay, from the lowest: compound 2; then compounds 1 and 3 (each within the scatter of the next); then compound 4.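

In this assay, for the compounds shown here, the step of a 7.9-fold higher number from compound 2 to compound 4 (0.90 log units; beyond the scatter) shows that this position responds to a change made on an oxygen on a saturated carbon, with the 3-hydroxypropyl chain left in place, whereas the earlier steps all exchanged the whole substituent on the aromatic carbon. The step runs toward lower toxicity in this test and is larger than any step among compounds 1, 2 and 3, so replacing the hydroxy group with benzoyloxy moved the read-out further than those exchanges did. Nothing available here explains why the benzoyl group has this effect.

The compounds shown leave open whether the shift belongs to the benzoyl group in particular or would also follow from a smaller acetyl group, a methyl ether or an amine in place of the hydroxy group. They also leave open whether the same benzoyl group on the oxygen of the 1-hydroxy-1-methylethyl group of compound 3 would move the read-out in the same direction, or whether a longer chain carrying the benzoyloxy group would keep the effect.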